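Dichlorophenyl for methoxyphenyl on the pyrimidinone core

This account rests on a few compounds, and the source may have more. Where it says the series, first, only, none or still open, it means among the compounds named here.

Compound 3 `COc1cccc(-c2nc(SCC(=O)c3sc(-c4ccccc4)nc3C)[nH]c(=O)c2C#N)c1` gives 99% in a functional assay on U-87MG ATCC cells for antiproliferative activity against U-87 MG (Homo sapiens), read by MTT assay, with a stated time of 48 h, tested at 5 uM (on this read-out lower numbers stand for a stronger effect and higher numbers for a weaker effect at the one concentration tested), the highest of the three numbers; compound 2 `COc1ccc(-c2nc(C)c(C(=O)CSc3nc(-c4cccc(OC)c4)c(C#N)c(=O)[nH]3)s2)cc1` gives 71.3% and compound 1 `COc1ccc(-c2nc(C)c(C(=O)CSc3nc(N)c(C#N)c(-c4ccc(Cl)cc4)n3)s2)cc1` gives 51.4%. Compound 4 `Cc1nc(-c2ccccc2)sc1C(=O)CSc1nc(-c2ccc(Cl)c(Cl)c2)c(C#N)c(=O)[nH]1` differs from compound 3 by 3,4-dichlorophenyl in place of 3-methoxyphenyl on an aromatic carbon. Among the measured compounds shown here, the only step between measured compounds, a number 27.7 percentage points higher from compound 2 to compound 3 (beyond the scatter), concerns hydrogen in place of methoxy on an aromatic carbon of a different ring, so no measured step bears directly on this change. Compound 1, with a chlorine-bearing phenyl on a different core, sits far lower, which gives only a loose hint. The step of a number 14 percentage points lower from compound 3 to compound 4 (beyond the scatter) is therefore expected to be modest and downward. Compound 4 is estimated at 85%, within 60% to 100%.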

Compound 4, a percentage reported as activity, at one concentration (the size of the read-out at that concentration, not a potency): 98.6%
The estimate for compound 4 lay 13.6 percentage points below the measured number, and the stated range covers the measured number.
By their numbers in this assay, from the lowest: compound 1; then compound 2; then compounds 4 and 3 (each within the scatter of the next).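

In this assay, 3,4-dichlorophenyl in place of 3-methoxyphenyl, on the aromatic carbon ortho to a cyano group, gives a number 0.4 percentage points lower from compound 3 to compound 4 (within the scatter). This read-out therefore does not separate the two aryl groups at this position, although the count of hydrogen-bond acceptors on the group falls from 1 to 0. No measurement at hand offers an explanation for this result. As far as these compounds go, it remains open how an amine or a carboxylic acid at this position would read, and whether 3,4-dichlorophenyl would give the same result alongside the methoxy group carried by compound 2.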